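A few compounds are considered here, and "the series" means these few. Any claim that something is new, unique, unknown or untested is made for them only; others in the source may bear on it.

Of the compounds shown here, three built on one shared core have been measured so far. In a functional assay on XF498 cells (Homo sapiens) for antiproliferative activity, read by MTT assay, with a stated time of 96 h (a lower number here means a stronger inhibitor, a higher number a weaker inhibitor), compound 1 `CCCc1ccc(N2C(=O)NC3(CSC4=C3C(=O)c3ncccc3C4=O)C2=O)cc1` gives 450 nM. Compound 2 `O=C1C2=C(C(=O)c3ncccc31)C1(CS2)NC(=O)N(c2ccc([N+](=O)[O-])cc2)C1=O` gives 1030 nM in this assay, and compound 3 `O=C1NN(c2ccc([N+](=O)[O-])cc2)C(=O)C2(CSC3=C2C(=O)c2ncccc2C3=O)N1` gives 4800 nM. Compound 2 thus holds the second highest of the three numbers: its nearest neighbour is compound 1 with the lower number, and its furthest is compound 3 with the higher one. Within the data shown here, the only single-place step among the measured compounds is a 2.3-fold higher number from compound 1 to compound 2 (0.36 log units; beyond the scatter), a modest rise.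

Compound 4 `CCCCc1ccc(N2C(=O)NC3(CSC4=C3C(=O)c3ncccc3C4=O)C2=O)cc1` has not yet been measured. It differs from compound 2 in one place: butyl in place of nitro on an aromatic carbon. The step from compound 1 to compound 2 bears directly on this change, since it runs the other way, nitro in place of propyl, and gave a modest rise. Among the measured compounds shown here, compound 4 returns an alkyl chain to that carbon, but with butyl rather than propyl; no measured pair separates butyl from propyl, so that part of the change has no support in the data. A modest fall in the number, roughly undoing the measured rise, is therefore expected, amounting to a 2.1-fold lower number from compound 2 to compound 4 (0.33 log units; beyond the scatter). Compound 4 is expected to give about 480 nM in this assay, within a range from 200 nM to 1200 nM.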

Compound 4, half-maximal inhibitory concentration: 950 nM
Compound 4: the middle estimate sits 2.0-fold (0.30 log units) below what was measured; the range from low to high includes it.
By their numbers in this assay, from the lowest: compound 1; then compounds 4 and 2 (each within the scatter of the next); then compound 3.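

In this assay, exchanging nitro for butyl on this aromatic carbon gives a 1.1-fold lower number from compound 2 to compound 4 (0.04 log units; within the scatter), so these two groups cannot be told apart here, even though the step from propyl to nitro was beyond the scatter. The one-carbon extension of the chain gives a 2.1-fold higher number from compound 1 to compound 4 (0.32 log units; beyond the scatter), a step close in size to the one from propyl to nitro, so an alkyl chain as such does not bring the lower number: among the compounds with this shared core and a hydantoin-free comparison aside, compound 1 stands apart from compound 4 and compound 2. No measured evidence accounts for this difference between propyl and butyl.

On these data alone, what remains open is whether the numbers would keep rising along the chain, as a longer chain such as hexyl would show, or whether a shorter ethyl group would match propyl. As far as these compounds go, how an amine or a carboxylic acid on this carbon would read also remains open.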